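This account rests on a few compounds, and the source may have more. Where it says the series, first, only, none or still open, it means among the compounds named here.

In a functional assay on HL-60 cells (Homo sapiens), with a stated time of 2 days (a lower number here means a stronger inhibitor, a higher number a weaker inhibitor), three compounds sharing one core have been measured. Compound 1 `CC(C)CNC(=O)c1[nH]cnc1C(=O)Nc1ccc(Cl)c(Cl)c1` gives 14700 nM, compound 2 `COc1ccc(CNC(=O)c2[nH]cnc2C(=O)Nc2ccc(Cl)c(Cl)c2)cc1` gives 24300 nM, and compound 3 `C[C@H](NC(=O)c1[nH]cnc1C(=O)Nc1ccc(Cl)c(Cl)c1)c1ccccc1` gives 9200 nM. Compound 3 therefore stands apart from compound 2 but cannot be separated from compound 1.

The next compound, compound 4 `C[C@H](NC(=O)c1[nH]cnc1C(=O)Nc1ccc(Cl)c(Cl)c1)C(=O)OC(C)(C)C`, differs from compound 3 by tert-butoxycarbonyl in place of phenyl on a saturated chain carbon bound to an amide-type nitrogen and a saturated chain carbon. In words, tert-butoxycarbonyl sits in place of phenyl on a saturated chain carbon bound to an amide-type nitrogen and a saturated chain carbon.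

Among the compounds with values here, no measured compound carries tert-butoxycarbonyl, so there is no direct precedent for this change. The nearest evidence is the set of changes to the group on the amide-type nitrogen. These gave a 1.6-fold lower number from compound 1 to compound 3 (0.20 log units; within the scatter) and a 1.7-fold higher number from compound 1 to compound 2 (0.22 log units; within the scatter), and only a 2.6-fold lower number from compound 2 to compound 3 (0.42 log units; beyond the scatter) exceeded the scatter. The first of these steps is the most relevant, since isobutyl in compound 1 also lacks a phenyl. A step of similar size is therefore expected in this assay, staying within the scatter and leaning slightly towards a higher number. The expected step is a 1.3-fold higher number from compound 3 to compound 4 (0.12 log units; within the scatter). The estimate for compound 4 is 12000 nM, with an expected range of 5000 nM to 30000 nM.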

Compound 4, half-maximal inhibitory concentration: 4900 nM
For compound 4 the middle estimate is 2.4-fold (0.39 log units) above the measured one; measured number below the stated range.
By their numbers in this assay, from the lowest: compounds 4, 3, 1 and 2 (each within the scatter of the next, the first and the last beyond it).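

In this assay, tert-butoxycarbonyl in place of phenyl on a saturated chain carbon bound to an amide-type nitrogen and a saturated chain carbon gives a step within the scatter (a 1.9-fold lower number from compound 3 to compound 4 (0.27 log units; within the scatter)), so at this position a group with no ring and with two hydrogen-bond acceptors cannot be told apart from the phenyl group it replaces. Within the data shown here, the change also yields the first compound that separates from the isobutyl amide (a 3.0-fold lower number from compound 1 to compound 4 (0.48 log units; beyond the scatter)), something compound 3 did not do, and it widens the distance from the 4-methoxybenzyl amide (a 5.0-fold lower number from compound 2 to compound 4 (0.70 log units; beyond the scatter)). Nothing in the data shown explains these steps.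

The compounds shown leave open whether the tert-butyl ester matters as a whole or whether its carbonyl alone carries the result, a question that a carboxylic acid, a methyl ester or a primary amide in the same place would address. They also leave open how the opposite configuration at the saturated chain carbon would read in this assay, since compound 3 and compound 4 share a single configuration there.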